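Nitrogen substituent series: isobutyl to cyclohexylmethyl

The source may hold more compounds than are shown below. What is called first, only, known or untested is meant among the compounds shown, and "the series" means these compounds.

Compound 1: `CC(C)c1onc(-c2c(Cl)cccc2Cl)c1COc1ccc(-c2nc3ccc(C(=O)O)cc3n2C2CCC2)cc1`, 14.4 nM
Compound 2: `CC(C)Cn1c(-c2ccc(OCc3c(-c4c(Cl)cccc4Cl)noc3C(C)C)cc2)nc2ccc(C(=O)O)cc21`, 5.26 nM

In an assay on Huh-7 cells for agonist activity at Bile acid receptor (Homo sapiens), read by a luciferase reporter (on this read-out higher numbers stand for an effect only at larger amounts of compound and lower numbers for an effect already at smaller amounts), compound 2 gives the lower of the two numbers. Among the measured compounds shown here, the one measured step, a 2.7-fold lower number from compound 1 to compound 2 (0.44 log units; beyond the scatter), is modest and beyond the scatter. Compound 3 `CC(C)c1onc(-c2c(Cl)cccc2Cl)c1COc1ccc(-c2nc3ccc(C(=O)O)cc3n2CC2CCCCC2)cc1` differs from compound 2 by cyclohexyl in place of isopropyl on a saturated chain carbon bound to an aromatic nitrogen. For the measured compounds named here, only that single step bears on this change; it shows the group on the aromatic nitrogen tolerates alteration, but no larger ring has been tested here. For compound 3 a step of a 1.1-fold higher number from compound 2 to compound 3 (0.06 log units; within the scatter) is expected, within the scatter. Compound 3 is estimated at 6 nM, range 2.5 nM to 15 nM.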

Compound 3, half-maximal effective concentration: 0.52 nM
Beside the measured number, compound 3's estimate is 12-fold (1.06 log units) above it, and the stated range ends above it.
By their numbers in this assay, from the lowest: compound 3; then compound 2; then compound 1.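

In this assay, the group on the aromatic nitrogen proves to be a strong lever on the number, not merely a tolerated change: cyclohexyl in place of isopropyl on the saturated chain carbon gives a 10-fold lower number from compound 2 to compound 3 (1.00 log units; beyond the scatter) and exceeds the earlier isobutyl step. Against the cyclobutyl group, cyclohexylmethyl gives a 28-fold lower number from compound 1 to compound 3 (1.44 log units; beyond the scatter) and sets the lowest number of the series. No evidence at hand accounts for this gain.

Still open, going by these compounds, is whether a cyclohexylethyl chain or a benzyl group on the aromatic nitrogen would hold this gain. Also open, on these data alone, is how a piperidine ring carrying an amine nitrogen in place of the cyclohexyl ring would read.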